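Sulfonyl in place of carbonyl on the aryl amine

The source may report more compounds than this note shows. Statements on the series, on what has been measured and on what is new or still open speak of the compounds shown alone.

Measured so far in a functional assay on MCF7 cells (Homo sapiens) for antiproliferative activity, read by MTT assay, with a stated time of 48 h; a higher number here means a weaker inhibitor, a lower number a stronger inhibitor:
compound 1, `O=C(Nc1cccc(/C=C/C(=O)c2nc3ccccc3[nH]2)c1)c1ccccc1`, 11200 nM
compound 2, `O=C(Nc1cccc(/C=C/C(=O)c2nc3ccccc3[nH]2)c1)c1ccc(Br)cc1`, 7000 nM
compound 3, `COc1ccc(C(=O)Nc2cccc(/C=C/C(=O)c3nc4ccccc4[nH]3)c2)cc1`, 20100 nM

Compound 3 gives the highest number of the three. The step from compound 1 to compound 3 is a 1.8-fold higher number from compound 1 to compound 3 (0.25 log units; within the scatter), whereas the step from compound 2 to compound 3 is a 2.9-fold higher number from compound 2 to compound 3 (0.46 log units; beyond the scatter), so compound 3 is separated clearly only from compound 2.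

Compound 4, `Cc1cccc(S(=O)(=O)Nc2cccc(/C=C/C(=O)c3nc4ccccc4[nH]3)c2)c1`, carries the change ((3-methylphenyl)sulfonyl in place of (4-methoxyphenyl)carbonyl on a nitrogen on an aromatic ring). Going by the values given here, no measured step touches this part of the molecule; the two steps that bear at all, a 1.8-fold higher number from compound 1 to compound 3 (0.25 log units; within the scatter) and a 2.9-fold higher number from compound 2 to compound 3 (0.46 log units; beyond the scatter), only show that swapping the small group on the outer ring moves this assay little. The loss of the methoxy group suggests a number expected nearer compound 1, but the direction is uncertain. Compound 4 is therefore estimated at 12000 nM, between 4000 nM and 40000 nM, an expected step of a 1.7-fold lower number from compound 3 to compound 4 (0.22 log units; within the scatter).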

Compound 4, half-maximal inhibitory concentration: 886 nM
For compound 4 the middle estimate is 14-fold (1.13 log units) above the measured one; measured number below the stated range.
By their numbers in this assay, from the lowest: compound 4; then compounds 2, 1 and 3 (each within the scatter of the next, the first and the last beyond it).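

On the nitrogen on an aromatic ring, swaps on the outer ring of the carbonyl compounds had moved this assay little, yet (3-methylphenyl)sulfonyl gives a 23-fold lower number from compound 3 to compound 4 (1.36 log units; beyond the scatter), along with a 7.9-fold lower number from compound 2 to compound 4 (0.90 log units; beyond the scatter) and a 13-fold lower number from compound 1 to compound 4 (1.10 log units; beyond the scatter). Going by these compounds alone, this position can therefore shift the number far more than the earlier compounds showed. No measurement shown explains this step.

Sulfonyl replaces carbonyl here while the outer ring's substituent also changes, so the share of each remains open. A (4-methoxyphenyl)sulfonyl group on the same nitrogen would separate the two.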